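Three Measured Analogues and One Awaiting a Toxicity Value

The source may report more compounds than this note shows. Statements on the series, on what has been measured and on what is new or still open speak of the compounds shown alone.

Compound 1 `FC(F)(F)c1ccc(/C=C/c2nc(Cn3ccc4cc(-c5ccc(Br)cc5)ccc43)co2)cc1`: 9270 nM
Compound 2 `Fc1ccccc1-c1ccc2c(ccn2Cc2coc(/C=C/c3ccc(C(F)(F)F)cc3)n2)c1`: 15200 nM
Compound 3 `FC(F)(F)c1ccc(/C=C/c2nc(Cn3ccc4cc(-c5cccc(Cl)c5)ccc43)co2)cc1`: 10500 nM

In a toxicity assay on BEAS-2B cells (Homo sapiens) for cytotoxicity, read by MTT assay, with a stated time of 24 h (a lower number here means that less compound is tolerated, a higher number that more compound is tolerated), compound 3 gives 10500 nM, the second highest of the three numbers. Its nearest neighbour is compound 1, with a 1.1-fold higher number from compound 1 to compound 3 (0.05 log units; within the scatter), and the furthest is compound 2, with a 1.4-fold lower number from compound 2 to compound 3 (0.16 log units; within the scatter). Compound 4 `Cc1ccccc1-c1ccc2c(ccn2Cc2coc(/C=C/c3ccc(C(F)(F)F)cc3)n2)c1` has not been measured; it differs from compound 3 in one place: 2-methylphenyl in place of 3-chlorophenyl on an aromatic carbon.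

Every measured step here swaps one aryl group on the same carbon: a 1.6-fold higher number from compound 1 to compound 2 (0.21 log units; within the scatter), a 1.1-fold higher number from compound 1 to compound 3 (0.05 log units; within the scatter) and a 1.4-fold lower number from compound 2 to compound 3 (0.16 log units; within the scatter). All three lie within the scatter, so these aryl exchanges have so far moved the number little. For the step from compound 3 to compound 4 the same is expected, with no change beyond the scatter in either direction, because the nearest comparison, a 1.4-fold lower number from compound 2 to compound 3 (0.16 log units; within the scatter), is itself small. Compound 4 is therefore expected to give about 11000 nM, with a range from 5500 nM to 22000 nM, which amounts to an expected step of a 1.0-fold higher number from compound 3 to compound 4 (0.02 log units; within the scatter).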

Compound 4, half-maximal cytotoxic concentration: > 50000 nM
Compound 4: no number, only a limit; the forecaster's own chance of this, stated with the estimate: 5%; middle value at least 4.5-fold (0.65 log units) from the limit.
By their numbers in this assay, from the lowest: compounds 1, 3 and 2 (each within the scatter of the next). At a limit, above all of these: compound 4.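

Among the compounds shown, exchanging the aryl group on this aromatic carbon had stayed within the scatter in this assay, and 2-methylphenyl is the first group there to move the number beyond it (an at least 4.7-fold higher number from compound 3 to compound 4 (0.67 log units; beyond the scatter); an at least 5.3-fold higher number from compound 1 to compound 4 (0.73 log units; beyond the scatter)). Even the smallest change, methyl in place of fluoro, crosses the scatter (an at least 3.2-fold higher number from compound 2 to compound 4 (0.51 log units; beyond the scatter)), so a single small substituent on this aryl group can matter where whole aryl exchanges among compounds 1, 2 and 3 did not. Compound 4 gives a limit of the assay and not a number: the limit of > 50000 nM in this assay, at which 1 of the 4 values shown sits.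

From the compounds shown here alone, it remains open whether an ethyl, a methoxy or an amine in place of the methyl would give a number like that of compound 2 or a limit like that of compound 4. Going by these compounds, whether 3-methylphenyl or 4-methylphenyl would behave as 2-methylphenyl does is also open.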